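This account rests on a few compounds, and the source may have more. Where it says the series, first, only, none or still open, it means among the compounds named here.

The measured compounds:
compound 1, `CNC(=O)c1c(O)c2cccnc2n(-c2ccccc2)c1=O`, which in a functional assay on the whole organism for inhibition, with Rattus norvegicus as the target, read by cytopathic effect and paw edema, at a dose of 100 mg/kg by the oral route (a lower number here means less inhibition, a higher number more inhibition at the dose given (going by the name of the read-out)), gives 21%;
compound 2, `CN(C)CCNC(=O)c1c(O)c2cccnc2n(-c2ccccc2)c1=O`, which in this assay gives 18.4%;
compound 3, `O=C(NC1CCN(Cc2ccccc2)CC1)c1c(O)c2cccnc2n(-c2ccccc2)c1=O`, which in this assay gives 1.2%.

Compound 2 stands second highest of these three numbers in this assay: compound 1 sits close to it, within the usual scatter, while compound 3 lies far below it, beyond the scatter. Compound 4, `O=C(Nc1ccc([N+](=O)[O-])cc1)c1c(O)c2cccnc2n(-c2ccccc2)c1=O`, has not yet been measured. It differs from compound 2 in one place: 4-nitrophenyl in place of 2-(dimethylamino)ethyl on an amide-type nitrogen.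

For the measured compounds named here, one measured step concerns the same amide-type nitrogen: a number 2.6 percentage points lower from compound 1 to compound 2 (within the scatter), a change too small to count. Going by the values given here, the pair of compound 2 and compound 3 shows that putting a group carrying a ring on that nitrogen went with a much lower number, though no step for that pair is available. Among the compounds with values here, no measured step brings an aromatic ring directly onto that nitrogen.

The step for compound 4 is expected to be a fall, a number 9.4 percentage points lower from compound 2 to compound 4 (within the scatter), beyond the scatter. Compound 4 is therefore estimated at 9%, with a range from 0% to 26%.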

Compound 4, a percentage reported as inhibition, in the whole organism at one dose (the size of the read-out at that dose, not a potency): -25.8%
For compound 4 the middle estimate is 34.8 percentage points above the measured one; the whole stated range lies above it.
By their numbers in this assay, from the lowest: compound 4; then compound 3; then compounds 2 and 1 (each within the scatter of the next).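

In this assay, the amide-type nitrogen proves sensitive to what it carries once an aromatic ring sits directly on it: a number 44.2 percentage points lower from compound 2 to compound 4 (beyond the scatter), and a number 46.8 percentage points lower from compound 1 to compound 4 (beyond the scatter). For the compounds shown here, the earlier change from methyl to 2-(dimethylamino)ethyl stayed within the scatter, whereas 4-nitrophenyl brings the first negative number in the set, with compound 4 at -25.8%. Nothing available here explains this fall.

The compounds shown leave open whether the fall goes with the aromatic ring itself or with the nitro group it carries; a plain phenyl or a 4-aminophenyl on the same nitrogen would separate the two. A benzyl group on that nitrogen would show whether the number depends on the ring being bound directly to it.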